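Adding a methyl group to the tetrazole of compound 2

The compounds below may be only part of what the source reports. "The series", "measured", "known", "first", "only" and "open" are said of these compounds alone.

In a functional assay on HUVEC cells (Homo sapiens), read by scintillation counting and thymidine incorporation, with a stated time of 24 h (a higher number here means a weaker inhibitor, a lower number a stronger inhibitor), compound 1 `CCC(C)n1ncn(-c2ccc(N3CCN(c4ccc(OC[C@@H]5CO[C@@](Cn6c(C)cnc6C)(c6ccc(Cl)cc6Cl)O5)cc4)CC3)cc2)c1=O` gives 765 nM. Compound 2 `CCC(C)n1ncn(-c2ccc(N3CCN(c4ccc(OC[C@@H]5CO[C@@](Cn6cnnn6)(c6ccc(Cl)cc6Cl)O5)cc4)CC3)cc2)c1=O` gives 73 nM, the lower of the two numbers, which makes it the stronger inhibitor so far. Compound 3 `CCC(C)n1ncn(-c2ccc(N3CCN(c4ccc(OC[C@@H]5CO[C@@](Cn6nnnc6C)(c6ccc(Cl)cc6Cl)O5)cc4)CC3)cc2)c1=O` keeps everything in compound 2 except one detail of the tetrazole: methyl in place of hydrogen on an aromatic carbon. This places methyl in place of hydrogen on an aromatic carbon, turning 1H-tetrazol-1-yl into 5-methyl-1H-tetrazol-1-yl. That carbon lies between two ring nitrogen atoms, next to the ring atom that bears a large group.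

For the measured compounds named here, no measured step isolates this change. The only one that bears on it is a 10-fold lower number from compound 1 to compound 2 (1.02 log units; beyond the scatter), a large step that replaced 2,5-dimethyl-1H-imidazol-1-yl with 1H-tetrazol-1-yl. It swapped the whole ring, so it offers only a weak hint that a methylated ring may sit on the weaker side. A small move toward a higher number is therefore expected, with an estimated 1.9-fold higher number from compound 2 to compound 3 (0.28 log units; within the scatter). The estimate for compound 3 is 140 nM, with a range of 45 nM to 400 nM.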

Compound 3, half-maximal inhibitory concentration: 101 nM
Compound 3: middle estimate off by 1.4-fold (0.14 log units), on the high side; the measured number falls inside the stated range.
By their numbers in this assay, from the lowest: compounds 2 and 3 (each within the scatter of the next); then compound 1.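

In this assay, placing a methyl group on the aromatic carbon between two ring nitrogen atoms gives a 1.4-fold higher number from compound 2 to compound 3 (0.14 log units; within the scatter), so this change leaves compound 2 and compound 3 indistinguishable, and the position accepts a methyl without a measurable penalty. The tetrazole also stays clearly apart from the dimethylimidazole once it carries a methyl, with a 7.6-fold lower number from compound 1 to compound 3 (0.88 log units; beyond the scatter), so a methyl group on the ring does not by itself bring the number back to that of compound 1, and the earlier hint about methylated rings gains no support here. No measurement in hand explains why either step has the size it does.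

The compounds shown leave open whether a longer chain such as ethyl, or an amine, on this same carbon would stay as close to compound 2 as methyl does. They also leave open where 1H-imidazol-1-yl without any methyl groups would fall, a value that would show how much of the gap to compound 1 belongs to the ring itself and how much to its two methyl groups.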